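Hydrazone Cytotoxicity: Bromophenyl to Fluorophenyl

This account rests on a few compounds, and the source may have more. Where it says the series, first, only, none or still open, it means among the compounds named here.

compound 1 `O=C(COc1cccc2ccccc12)N/N=C/c1ccc(O)cc1`: 20 ug/mL
compound 2 `O=C(COc1cccc2ccccc12)N/N=C/c1cccc(Br)c1`: 100 ug/mL

Within the data shown here, in an ADME assay on HEL cells (Homo sapiens) for cytotoxicity (a lower number here means that less compound is tolerated, a higher number that more compound is tolerated), compound 2 stands highest of the two numbers measured; its only neighbour is compound 1, separated by a 5.0-fold higher number from compound 1 to compound 2 (0.70 log units; beyond the scatter). Compound 3 `O=C(COc1cccc2ccccc12)N/N=C/c1ccc(F)cc1` differs from compound 2 by 4-fluorophenyl in place of 3-bromophenyl on a carbon with a double bond to nitrogen. Among the measured compounds shown here, no measured step bears directly on this exchange; the single step shows only that replacing the aryl group moved this assay modestly. A somewhat lower number is therefore expected for compound 3, with a 2.0-fold lower number from compound 2 to compound 3 (0.30 log units; within the scatter). Compound 3 is estimated at 50 ug/mL, within 20 ug/mL to 100 ug/mL.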

Compound 3, minimum cytotoxic concentration: 100 ug/mL
Compound 3: middle estimate off by 2.0-fold (0.30 log units), on the low side, and the stated range covers the measured number.
By their numbers in this assay, from the lowest: compound 1; then compounds 2 and 3 (each within the scatter of the next).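

In this assay the exchange of 3-bromophenyl for 4-fluorophenyl on a carbon with a double bond to nitrogen gives no change at the digits printed from compound 2 to compound 3 (within the scatter) and so does not separate these two aryl groups, although the halogen and its ring position change together. Fluoro in place of hydroxy on an aromatic carbon gives a 5.0-fold higher number from compound 1 to compound 3 (0.70 log units; beyond the scatter) and sets compound 1 apart from both halogen-bearing compounds. No evidence accounts for this difference. On these data alone, whether an amine or a carboxylic acid on the aromatic ring would track with hydroxy or with the halogens remains open. So does the effect of bromo and fluoro at the same ring position.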